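From 2-Aminophenyl to Pyridin-4-yl: Expected Cytotoxicity

The source may hold more compounds than are shown below. What is called first, only, known or untested is meant among the compounds shown, and "the series" means these compounds.

Measured so far:
compound 1, `Cc1ncc([N+](=O)[O-])n1CCSc1nnc(-c2ccccc2N)o1` — 35100 nM
compound 2, `COc1cc(-c2nnc(SCCn3c([N+](=O)[O-])cnc3C)o2)cc(OC)c1OC` — 34800 nM

In a functional assay on SGC-7901 cells (Homo sapiens) for cytotoxicity, read by MTT assay, with a stated time of 48 h (a lower number here means a stronger inhibitor, a higher number a weaker inhibitor), compound 1 gives 35100 nM. Of the two numbers in hand it is the higher one, but only just: compound 2 gives 34800 nM, and the gap between the two lies within the usual scatter, so nothing separates them. The two compounds share a core and differ widely in the aromatic group attached to it, yet their numbers coincide, which suggests that this part of the molecule matters little for the read-out, at least across these two examples.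

Compound 3, `Cc1ncc([N+](=O)[O-])n1CCSc1nnc(-c2ccncc2)o1`, is not yet measured. It is derived from compound 1 by the following change: pyridin-4-yl in place of 2-aminophenyl on an aromatic carbon. Among the measured compounds shown here, no comparable step between measured compounds exists to calibrate this swap. Given that compound 1 and compound 2 sit together despite their very different aromatic groups, a step beyond the scatter in either direction is not expected. Compound 3 is therefore estimated to give 35000 nM, with a range from 12000 nM to 100000 nM. The expected step of a 1.0-fold lower number from compound 1 to compound 3 (0.00 log units; within the scatter) is essentially none.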

Compound 3, half-maximal inhibitory concentration: 15900 nM
Compound 3: middle estimate off by 2.2-fold (0.34 log units), on the high side; low and high end bracket the measured number.
By their numbers in this assay, from the lowest: compound 3; then compounds 2 and 1 (each within the scatter of the next).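

In this assay pyridin-4-yl in place of 2-aminophenyl gives a 2.2-fold lower number from compound 1 to compound 3 (0.34 log units; beyond the scatter) and so shows that the aromatic carbon of the five-membered aromatic ring with 2 nitrogen and 1 oxygen is not indifferent to what it carries, a point the two earlier compounds, with their matching numbers, could not reveal. Among the compounds shown here, the step is modest, but it is the first difference in this small set to stand clear of the scatter, and it comes with a change from a six-membered aromatic ring of carbon only to one with 1 hetero atom, and from 1 hydrogen-bond donor to 0 hydrogen-bond donors. No measurement shown here explains the step or says which of these differences counts.

The compounds shown leave open whether the gain follows from the ring nitrogen of pyridin-4-yl or from the loss of the amine of 2-aminophenyl, a question that a plain phenyl group at the same carbon would help to separate. A pyridin-3-yl or pyridin-2-yl group would in turn show whether the place of the ring nitrogen matters.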